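The source may report more compounds than this note shows. Statements on the series, on what has been measured and on what is new or still open speak of the compounds shown alone.

In a functional assay on OVCAR-3 cells (Homo sapiens) for cytotoxicity, read by sulforhodamine B assay (on this read-out higher numbers stand for lower toxicity in this test and lower numbers for higher toxicity in this test), compound 1 `CC1=CC[C@@H]([C@@](C)(O)CCCC(C)(C)NC(=S)N/N=C\c2ccccc2)CC1` gives 43600 nM and compound 2 `CC1=CC[C@@H]([C@@](C)(O)CCCC(C)(C)NC(=S)N/N=C\c2ccccc2[N+](=O)[O-])CC1` gives 41900 nM, so compound 2 stands within the scatter of compound 1. Compound 3 `CC1=CC[C@@H]([C@@](C)(O)CCCC(C)(C)NC(=S)N/N=C\c2ccc(Cl)cc2)CC1` remains unmeasured. The structural change is 4-chlorophenyl in place of 2-nitrophenyl on a carbon with a double bond to nitrogen. Within the data shown here, the only measured step on this aromatic ring is a 1.0-fold lower number from compound 1 to compound 2 (0.02 log units; within the scatter), and no chlorine-bearing compound has a value yet. No step beyond the scatter is therefore expected in this assay. The expected step is a 1.2-fold lower number from compound 2 to compound 3 (0.07 log units; within the scatter). For compound 3 the estimated value is 36000 nM, with an expected range of 16000 nM to 75000 nM.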

Compound 3, concentration lethal to 50% of the cells: 40600 nM
The estimate for compound 3 lay 1.1-fold (0.05 log units) below the measured number; the range from low to high includes it.
By their numbers in this assay, from the lowest: compounds 3, 2 and 1 (each within the scatter of the next).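

In this assay, 4-chlorophenyl in place of 2-nitrophenyl on a carbon with a double bond to nitrogen gives a 1.0-fold lower number from compound 2 to compound 3 (0.01 log units; within the scatter) and a chlorine-bearing ring in place of the unsubstituted ring gives a 1.1-fold lower number from compound 1 to compound 3 (0.03 log units; within the scatter) in this series. A chlorine-bearing ring therefore joins the nitro-bearing and unsubstituted rings, with all three compounds within the scatter of one another. No evidence bears on this result.

From the compounds shown here alone, whether an amine or a carboxylic acid on this aromatic ring would give a step beyond the scatter remains open. So does the effect of a longer chain in place of the ring.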